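A few compounds are considered here, and "the series" means these few. Any claim that something is new, unique, unknown or untested is made for them only; others in the source may bear on it.

Of the compounds shown here, three with a shared core have been measured in an ADME assay on L02 cells (Homo sapiens) for cytotoxicity, read by MTT assay, with a stated time of 72 h; on this read-out higher numbers stand for weaker inhibition and lower numbers for stronger inhibition. There, compound 1 `O=C(O)CCC(=O)OCCCCCCSc1ccc([N+](=O)[O-])c2nonc12` gives 1890 nM, compound 2 `O=C(CCC(=O)OCCCCCCSc1ccc([N+](=O)[O-])c2nonc12)Nc1ccc(C(F)(F)F)cc1` gives 5010 nM and compound 3 `COc1ccc(NC(=O)CCC(=O)OCCCCCCSc2ccc([N+](=O)[O-])c3nonc23)cc1OC` gives 4100 nM. Compound 3 therefore stands level with compound 2 at the upper end of these numbers, the step between them being a 1.2-fold lower number from compound 2 to compound 3 (0.09 log units; within the scatter), while compound 1 lies clearly lower.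

Compound 4 `O=C(CCC(=O)N1CCOCC1)OCCCCCCSc1ccc([N+](=O)[O-])c2nonc12` differs from compound 3 in one place, with morpholin-4-yl in place of (3,4-dimethoxyphenyl)amino on a carbonyl carbon. The measured steps at this carbonyl carbon are a 2.7-fold higher number from compound 1 to compound 2 (0.42 log units; beyond the scatter) and a 2.2-fold higher number from compound 1 to compound 3 (0.34 log units; beyond the scatter). Both are modest, and both start from hydroxy. Among the compounds with values here, no measured compound carries morpholin-4-yl, so these steps only suggest how far a change at this carbon has moved the number so far. No change beyond the scatter is expected in this assay, with a slight drift toward compound 1 at most. The expected step is a 1.2-fold lower number from compound 3 to compound 4 (0.07 log units; within the scatter). The estimated value for compound 4 is 3500 nM, with an expected range from 1500 nM to 8000 nM.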

Compound 4, half-maximal inhibitory concentration: 3240 nM
For compound 4 the middle estimate is 1.1-fold (0.03 log units) above the measured one, within the range that was stated.
By their numbers in this assay, from the lowest: compounds 1, 4, 3 and 2 (each within the scatter of the next, the first and the last beyond it).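

In this assay the step of a 1.3-fold lower number from compound 3 to compound 4 (0.10 log units; within the scatter) and the step of a 1.5-fold lower number from compound 2 to compound 4 (0.19 log units; within the scatter) both lie within the scatter, so morpholin-4-yl, with its non-aromatic ring and no hydrogen-bond donor, is not told apart at this carbonyl carbon from the two arylamino groups. The step of a 1.7-fold higher number from compound 1 to compound 4 (0.23 log units; within the scatter) is also within the scatter, which sets morpholin-4-yl apart from those two groups, as their steps from hydroxy lie beyond it. The data at hand offer no measured finding that would account for any of this.

The compounds shown leave open how a piperidin-1-yl or piperazin-1-yl group, or a simple primary amide, would fare on this carbonyl carbon. They also leave open whether morpholin-4-yl would give the same picture on a shorter or longer chain.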